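Hydroxy in place of hydrogen on the chain of compound 2

The source may report more compounds than this note shows. Statements on the series, on what has been measured and on what is new or still open speak of the compounds shown alone.

Compound 1 `COc1ccc2nc(C)cc(SCc3ccccc3)c2c1` gives (30600 nM)
Compound 2 `CCCCCCOc1ccc2nc(C)cc(NCc3ccc(F)cc3)c2c1` gives (8800 nM)

In a functional assay on MCF-10A cells (Homo sapiens) for antiproliferative activity, with a stated time of 48 h (on this read-out lower numbers stand for an effect already at smaller amounts and higher numbers for an effect only at larger amounts of compound), compound 1 gives 30600 nM and compound 2 gives 8800 nM. Compound 2 holds the lower of the two numbers, and the gap between them lies beyond the scatter. Compound 3 `Cc1cc(NCc2ccc(F)cc2)c2cc(OCCCCCCO)ccc2n1` differs from compound 2 by a single change (hydroxy in place of hydrogen on a saturated chain carbon, six bonds along the chain from an oxygen on an aromatic ring): hydroxy in place of hydrogen on a saturated chain carbon, six bonds along the chain from an oxygen on an aromatic ring. For the measured compounds named here, no measured pair shows this change, so the expectation is loose: a modest rise in the number, perhaps none beyond the scatter. The expected step is small (a 1.6-fold higher number from compound 2 to compound 3 (0.20 log units; within the scatter)). In this assay compound 3 is estimated at 14000 nM (range 5000 nM to 35000 nM).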

Compound 3, half-maximal effective concentration: 8100 nM
Compound 3: the middle estimate sits 1.7-fold (0.24 log units) above what was measured, and the stated range covers the measured number.
By their numbers in this assay, from the lowest: compounds 3 and 2 (each within the scatter of the next); then compound 1.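

For the compounds shown here, the step from hydrogen to hydroxy on the saturated chain carbon, six bonds along the chain from an oxygen on an aromatic ring, is the first single change that can be read in (this assay). It comes to (a 1.1-fold lower number from compound 2 to compound 3 (0.04 log units; within the scatter)), so at this position the hydroxy leaves the number where it was, which neither earlier compound could show. No measurement at hand offers a reason for this. As far as these compounds go, whether an amine or a carboxylic acid in place of the hydroxy, or a longer chain, would leave the number equally unchanged remains open.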